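The compounds below may be only part of what the source reports. "The series", "measured", "known", "first", "only" and "open" are said of these compounds alone.

Among the compounds with values here, compound 2, `C[C@@H](NC(=O)Nc1cccc(F)c1)c1ccccc1`, is the higher of the two numbers measured so far: in an ADME assay on the whole organism with Oryza sativa as the target, tested at 1 uM (a lower number here means a stronger effect, a higher number a weaker effect of the compound at the concentration tested), compound 2 gives 95%. Within the data shown here, its nearest neighbour is compound 1, `CC(=O)c1cccc(NC(=O)N[C@H](C)c2ccccc2)c1`, which in this assay gives 88%, and the one step that joins them, a number 7 percentage points higher from compound 1 to compound 2 (within the scatter), stays within the scatter of the method. The next compound, compound 3, `C[C@@H](NC(=O)Nc1cccc(Cl)c1)c1ccccc1`, differs from compound 2 in a single place: chloro in place of fluoro on an aromatic carbon. Among the measured compounds shown here, no measured step exchanges one halogen for another, so nothing in the data speaks directly to this change; the only step available, from compound 1 to compound 2, shows that a different exchange on the same aromatic carbon left the read-out essentially where it was. On that basis the expected step in this assay from compound 2 to compound 3 is a number 3 percentage points lower from compound 2 to compound 3 (within the scatter), that is, no shift beyond the scatter in either direction. Compound 3 is therefore estimated in this assay at 92%, with a range from 78% to 100% expected to hold most repeat measurements.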

Compound 3, a percentage reported as activity, at one concentration (the size of the read-out at that concentration, not a potency): 91%
The estimate for compound 3 lay 1 percentage points above the measured number; the measured number falls inside the stated range.
By their numbers in this assay, from the lowest: compounds 1, 3 and 2 (each within the scatter of the next).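

With chloro in place of fluoro on this aromatic carbon, meta to a large group, this assay now has a step that exchanges one halogen for another, a number 4 percentage points lower from compound 2 to compound 3 (within the scatter), and this exchange does not move the read-out beyond the scatter. The exchange of acetyl for chloro at the same place, a number 3 percentage points higher from compound 1 to compound 3 (within the scatter), also stays within the scatter, so acetyl, fluoro and chloro at this position are not told apart by this assay, and the earlier result for fluoro no longer stands alone. No measurement at hand offers any explanation for this sameness among the three groups.

The compounds shown leave open whether any group at this position can shift the read-out beyond the scatter, for a group of another kind, such as an amine, a carboxylic acid or a longer chain, does not appear among them. They also leave open whether chloro would give the same read-out on another carbon of this ring, since all three compounds carry their varied group at the same place on an otherwise unchanged core.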